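A Cinnamoyl Amide Replaces the Chlorobenzamide on a Shared Core

This account rests on a few compounds, and the source may have more. Where it says the series, first, only, none or still open, it means among the compounds named here.

Measured compounds:
- compound 1 `Cc1nnc(Sc2cc(NC(=O)c3ccc(Cl)cc3)c3ccccc3c2O)s1`: in a functional assay on HCT-116 cells (Homo sapiens) for antiproliferative activity, read by MTT assay, with a stated time of 48 h (a lower number here means a stronger inhibitor, a higher number a weaker inhibitor), compound 1 gives > 100000 nM
- compound 2 `O=C(Nc1cc(Sc2ncn[nH]2)c(O)c2ccccc12)c1cccc(Cl)c1`: in this assay compound 2 gives > 100000 nM
- compound 3 `O=C(Nc1cc(Sc2ncnc3nc[nH]c23)c(O)c2ccccc12)c1ccc(Cl)cc1`: in this assay compound 3 gives > 100000 nM

Each of these values is a limit of the assay, not a number. Compound 2 therefore stands at that limit, and the two further values around it are limits as well (the limit of > 100000 nM in this assay, at which 3 of the 3 values shown sit). Among the measured compounds shown here, the one step among measured compounds that differs in a single place, a step that the two limits leave unreadable from compound 1 to compound 3, runs between two limits and cannot be read in size or direction, so no measured step bears on the change now followed.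

Compound 4 `O=C(/C=C/c1ccccc1)Nc1cc(Sc2ncn[nH]2)c(O)c2ccccc12` differs from compound 2 at the carbonyl carbon: 2-phenylethenyl in place of 3-chlorophenyl on a carbonyl carbon. For the measured compounds named here, no pair of measured compounds shows what such a change does, so the expectation rests on where compound 2 stands. Compound 4 is expected to remain at or near the limit, with the step from compound 2 estimated as a number no higher from compound 2 to compound 4 (the limit leaves the size open). Compound 4 is thus estimated at 100000 nM, in a range from 20000 nM to 300000 nM.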

Compound 4, half-maximal inhibitory concentration: > 100000 nM
Compound 4 was reported as a limit; the forecaster's own chance of this, stated with the estimate: 65%; the middle value lies on the limit itself.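

Compound 4 gives > 100000 nM in this assay, which is a limit and not a number. Among the compounds shown here, compound 2 and compound 4 thus offer no step that can be read: the limit of > 100000 nM in this assay, at which 4 of the 4 values shown sit. The compounds shown leave open which change to the shared core, if any, would give a measurable value in this assay.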